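Side chains on the shared core: oxygen-bearing chain to hydrocarbon

A few compounds are considered here, and "the series" means these few. Any claim that something is new, unique, unknown or untested is made for them only; others in the source may bear on it.

Values in an assay on cells with melanin-concentrating hormone receptor 1 (Homo sapiens) as the target, read by radioligand binding; on this read-out lower numbers stand for stronger inhibition and higher numbers for weaker inhibition:
- compound 1 `CCOCC(C)Oc1cccc2ccc(N)nc12`: 1070 nM
- compound 2 `COC(C)(C)CCOc1cccc2ccc(N)nc12`: 132 nM
- compound 3 `CCC#CCOc1cccc2ccc(N)nc12`: > 2000 nM

Of the two numbers in hand, compound 1 has the higher and compound 2 the lower, a gap beyond the scatter. For compound 3 the reading is only a limit, (the limit of > 2000 nM in this assay, at which 1 of the 3 values shown sits).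

Compound 4 `Nc1ccc2cccc(OCCC3CC3)c2n1` is the next case; its change from compound 1 is a group of 5 heavy atoms (5 carbon; one three-membered non-aromatic ring of carbon only) in place of a group of 6 heavy atoms (5 carbon, 1 oxygen; no ring), on an oxygen on an aromatic ring. Both measured steps that take the oxygen out of the chain bear on it. The step of an at least 1.8-fold higher number from compound 1 to compound 3 (0.27 log units; that floor lies within the scatter) went toward a weaker number, though only its floor is known. The step of an at least 15-fold higher number from compound 2 to compound 3 (1.18 log units; beyond the scatter) was the large one. Compound 4 keeps a hydrocarbon chain of the same atom count as compound 3, so a move toward a higher number is expected, of a size a 1.9-fold higher number from compound 1 to compound 4 (0.27 log units; within the scatter), with a fair chance that only a limit is returned. The estimate for compound 4 in this assay is 2000 nM, expected between 700 nM and 6000 nM.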

Compound 4, half-maximal inhibitory concentration: 492 nM
Estimate against measurement, compound 4: 4.1-fold (0.61 log units) above; measured number outside the range, below it.
By their numbers in this assay, from the lowest: compound 2; then compound 4; then compound 1. At a limit, above all of these: compound 3.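

In this assay, a chain without oxygen, on an oxygen on an aromatic ring, need not lose ground: 2-cyclopropylethyl gives a 2.2-fold lower number from compound 1 to compound 4 (0.34 log units; beyond the scatter), while compound 3 goes against this direction. Among the hydrocarbon chains, cyclopropylmethyl in place of but-1-yn-1-yl gives an at least 4.0-fold lower number from compound 3 to compound 4 (0.60 log units; beyond the scatter); that size is only a floor, as the reading for compound 3 is a limit: the limit of > 2000 nM in this assay, at which 1 of the 4 values shown sits. The oxygen-bearing chain of compound 2 still holds the lowest number, with cyclopropyl in place of 1-methoxy-1-methylethyl giving a 3.7-fold higher number from compound 2 to compound 4 (0.57 log units; beyond the scatter), so the presence or absence of chain oxygen alone does not set the order here.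

On these data alone, how much of the gain in compound 4 belongs to the cyclopropyl ring rather than to the saturated chain remains open. Also open, as far as these compounds go, is how a longer chain, or an amine or carboxylic acid at the chain end, would read at this position.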